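This account rests on a few compounds, and the source may have more. Where it says the series, first, only, none or still open, it means among the compounds named here.

Measured so far in a functional assay on MDA-MB-231 cells (Homo sapiens) for antiproliferative activity, read by MTT assay, with a stated time of 72 h; a lower number here means a stronger inhibitor, a higher number a weaker inhibitor:
- compound 1 `NC1=NC2(CCSCC2)N(OCCCOc2ccc(Cl)c(Cl)c2)C(N)=N1` gives 10 nM
- compound 2 `NC1=NC2(CCOCC2)N(OCCCOc2cccc(Cl)c2Cl)C(N)=N1` gives 140 nM

Compound 2 holds the higher of these two numbers, so it is the weaker inhibitor of the pair, and the gap to compound 1 lies beyond the scatter. These two compounds differ in more than one place, so their gap cannot be assigned to any single change.

Next comes compound 3 `NC1=NC2(CCOCC2)N(OCCCOc2cccc(Br)c2)C(N)=N1`, not yet measured, which keeps the core of compound 2. The change is 3-bromophenyl in place of 2,3-dichlorophenyl on an oxygen on a saturated carbon. For the measured compounds named here, no measured pair shows this change, so the data give no direct guide to its size or direction. In this assay no step beyond the scatter is expected, and the range is kept wide on both sides. The estimated step of a 1.3-fold lower number from compound 2 to compound 3 (0.10 log units; within the scatter) is expected to be small. Compound 3 is expected at 110 nM (estimated range 30 nM to 400 nM).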

Compound 3, half-maximal inhibitory concentration: 400 nM
Beside the measured number, compound 3's estimate is 3.6-fold (0.56 log units) below it; low and high end bracket the measured number.
By their numbers in this assay, from the lowest: compound 1; then compound 2; then compound 3.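

In this assay, for the compounds shown here, the group on the oxygen on a saturated carbon now gives the first single-change reading: 3-bromophenyl in place of 2,3-dichlorophenyl produces a 2.9-fold higher number from compound 2 to compound 3 (0.46 log units; beyond the scatter), a modest loss of potency. The aryl group at this place therefore affects the read-out on the core of compound 2, and of the two groups compared there, 2,3-dichlorophenyl gives the stronger inhibitor. No available measurement accounts for this step.

This single pair changes the halogen, the number of halogens and the substitution pattern together, so it cannot separate their contributions; 3-chlorophenyl, 2-chlorophenyl or unsubstituted phenyl on the same core would each leave fewer differences to compare. The steps from compound 1 to compound 2 and to compound 3 cannot be read because compound 1 differs from each in more than one place, which also leaves open whether the aryl effect carries over to the core of compound 1.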